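Adding diethylamino to the propyl chain of compound 3

The compounds below may be only part of what the source reports. "The series", "measured", "known", "first", "only" and "open" are said of these compounds alone.

In a functional assay on cells (Homo sapiens) for antiproliferative activity, read by MTT assay, with a stated time of 48 h (on this read-out higher numbers stand for weaker inhibition and lower numbers for stronger inhibition), compound 3 (`CCCn1c(N)c(-c2nc3ccccc3[nH]2)c2nc(C#N)c(C#N)nc21`) stands at > 50000 nM which is a limit of the assay and not a number. Compound 4 (`CCN(CC)CCCn1c(N)c(-c2nc3ccccc3[nH]2)c2nc(C#N)c(C#N)nc21`) carries diethylamino in place of hydrogen on a saturated chain carbon, three bonds along the chain from an aromatic nitrogen. Compound 1 (`CCN(CC)CCn1c(N)c(-c2nc3ccccc3[nH]2)c2nc(C#N)c(C#N)nc21`) has diethylamino two bonds along the chain and gives 25400 nM while compound 2 (`CN1CCN(CCn2c(N)c(-c3nc4ccccc4[nH]3)c3nc(C#N)c(C#N)nc32)CC1`) has 4-methylpiperazin-1-yl there and gives 9110 nM in the same test. Two measured changes bear on this: an at least 1.9-fold higher number from compound 1 to compound 3 (0.29 log units; that floor lies within the scatter) and an at least 5.4-fold higher number from compound 2 to compound 3 (0.73 log units; beyond the scatter) both run toward higher numbers. Read in reverse, they suggest a modest move to a lower number, so the expected change is an at least 2.5-fold lower number from compound 3 to compound 4 (0.39 log units; beyond the scatter) in this estimate. For compound 4 the estimated value is 20000 nM with an expected range from 8000 nM to 50000 nM in this test.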

Compound 4, half-maximal inhibitory concentration: 28900 nM
For compound 4 the middle estimate is 1.4-fold (0.16 log units) below the measured one; low and high end bracket the measured number.
By their numbers in this assay, from the lowest: compound 2; then compounds 1 and 4 (each within the scatter of the next). At a limit, above all of these: compound 3.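

Compound 3 is held at a limit and not a number in this assay: the limit of > 50000 nM in this assay, at which 1 of the 4 values shown sits. Adding diethylamino to its propyl chain gives an at least 1.7-fold lower number from compound 3 to compound 4 (0.23 log units; that floor lies within the scatter), so the gain can be read only as a floor that does not clear the scatter. The 2-(diethylamino)ethyl and 3-(diethylamino)propyl chains cannot be told apart, at a 1.1-fold higher number from compound 1 to compound 4 (0.06 log units; within the scatter), while 4-methylpiperazin-1-yl on the shorter chain remains ahead, at a 3.2-fold higher number from compound 2 to compound 4 (0.50 log units; beyond the scatter).

From the compounds shown here alone, whether 4-methylpiperazin-1-yl would hold that lead on the propyl chain remains open. So does the effect of a morpholine or a primary amine in place of diethylamino.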